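One fluoro added to compound 3

The source may report more compounds than this note shows. Statements on the series, on what has been measured and on what is new or still open speak of the compounds shown alone.

Measured in a functional assay on A549 cells (Homo sapiens) for cytotoxicity, read by MTT assay, with a stated time of 72 h; a lower number here means a stronger inhibitor, a higher number a weaker inhibitor:
- Compound 1 `CNC(=O)c1cc(Oc2ccc(NC(=O)c3cc(-c4ccc(Cl)cc4)ncn3)cc2F)ccn1` gives > 100000 nM, which is a limit.
- Compound 2 `CNC(=O)c1cc(Oc2ccc(NC(=O)c3cc(-c4ccc(Br)cc4)ncn3)cc2F)ccn1` gives > 100000 nM, which is a limit.
- Compound 3 `CNC(=O)c1cc(Oc2ccc(NC(=O)c3cc(-c4ccccc4)ncn3)cc2)ccn1` gives 27100 nM.

Among the compounds with values here, compound 3 holds the only true number here, 27100 nM. The other two results are limits: the limit of > 100000 nM in this assay, at which 2 of the 3 values shown sit. Compound 4 `CNC(=O)c1cc(Oc2ccc(NC(=O)c3cc(-c4ccccc4)ncn3)cc2F)ccn1` differs from compound 3 by one change, (fluoro in place of hydrogen on an aromatic carbon), ortho to a (2-(methylcarbamoyl)pyridin-4-yl)oxy group. Within the data shown here, the one measured step, a step that the two limits leave unreadable from compound 1 to compound 2, has no readable size and involves a different swap, so it offers no guide. Compound 1 and compound 2 carry this same fluoro, but each also has a chloro or bromo group, so they hint only weakly at weaker inhibition. The expected step is small, a 1.5-fold higher number from compound 3 to compound 4 (0.17 log units; within the scatter). For compound 4 the estimate is 40000 nM, with an expected range of 15000 nM to 100000 nM.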

Compound 4, half-maximal inhibitory concentration: 23200 nM
The estimate for compound 4 lay 1.7-fold (0.24 log units) above the measured number; the measured number falls inside the stated range.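

In this assay, the fluoro ortho to a (2-(methylcarbamoyl)pyridin-4-yl)oxy group has, taken alone, no effect that stands out from the scatter: a 1.2-fold lower number from compound 3 to compound 4 (0.07 log units; within the scatter). With that fluoro kept, hydrogen in place of bromo gives an at least 4.3-fold lower number from compound 2 to compound 4 (0.63 log units; beyond the scatter), and hydrogen in place of chloro gives an at least 4.3-fold lower number from compound 1 to compound 4 (0.63 log units; beyond the scatter), so the weak results of compound 1 and compound 2 go with those halogens, not with the fluoro. Both steps are minimum sizes, set by a limit: the limit of > 100000 nM in this assay, at which 2 of the 4 values shown sit.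

Going by these compounds, whether a methoxy group or an amine at this position would read the same stays open. So does how chloro or bromo would read on compound 3, without the fluoro.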